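Methoxy for Bromo on a Ret Kinase Urea Series

The compounds below may be only part of what the source reports. "The series", "measured", "known", "first", "only" and "open" are said of these compounds alone.

compound 1 `O=C(Nc1ccc(Nc2ncnc3c2OCCN3)cc1)Nc1ccc(Cl)c(C(F)(F)F)c1`: 188 nM
compound 2 `O=C(Nc1ccc(Cl)cc1)Nc1ccc(Nc2ncnc3c2OCCN3)cc1`: 2280 nM
compound 3 `O=C(Nc1ccc(Br)cc1)Nc1ccc(Nc2ncnc3c2OCCN3)cc1`: 2350 nM

In an assay on isolated protein for inhibition of proto-oncogene tyrosine-protein kinase receptor Ret variant V804M (Homo sapiens), read by 33P incorporation, with stated times of 15 min and 40 min (on this read-out higher numbers stand for weaker inhibition and lower numbers for stronger inhibition), compound 3 gives 2350 nM and stands with compound 2 at the weak end of the three numbers, the pair separated only by a 1.0-fold higher number from compound 2 to compound 3 (0.01 log units; within the scatter), while compound 1 lies well apart, as a 12-fold higher number from compound 1 to compound 2 (1.08 log units; beyond the scatter) shows. Compound 4 `COc1ccc(NC(=O)Nc2ccc(Nc3ncnc4c3OCCN4)cc2)cc1` differs from compound 3 by methoxy in place of bromo on an aromatic carbon. Within the data shown here, the step of a 1.0-fold higher number from compound 2 to compound 3 (0.01 log units; within the scatter) bears most directly on it, showing that swapping one small group for another at this carbon changed nothing beyond the scatter; no measured step covers methoxy itself. Compound 4 is therefore expected to stay close to compound 3, with a step of about a 1.3-fold higher number from compound 3 to compound 4 (0.11 log units; within the scatter). The estimated value of compound 4 is 3000 nM, with a range of 1000 nM to 9000 nM.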

Compound 4, half-maximal inhibitory concentration: 824 nM
Beside the measured number, compound 4's estimate is 3.6-fold (0.56 log units) above it; measured number outside the range, below it.
By their numbers in this assay, from the lowest: compound 1; then compound 4; then compounds 2 and 3 (each within the scatter of the next).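

Chloro and bromo had given matching numbers at this aromatic carbon, yet in this assay methoxy gives a 2.9-fold lower number from compound 3 to compound 4 (0.46 log units; beyond the scatter) and a 2.8-fold lower number from compound 2 to compound 4 (0.44 log units; beyond the scatter), a modest change in both cases. The match between the two halogens therefore does not extend to methoxy, so this position does respond to the group it carries. No evidence here explains the difference. As far as these compounds go, whether an amine, a hydroxy group or ethoxy would follow methoxy remains open. So does whether methoxy would give a similar step in a compound that also carries trifluoromethyl.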